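The source may hold more compounds than are shown below. What is called first, only, known or untested is meant among the compounds shown, and "the series" means these compounds.

The measured compounds:

Compound 1, `CCOC(=O)C1=C(Nc2ccccc2)S/C(=C\c2ccc(OC)cc2)C1=O`: in a functional assay on MCF7 cells (Homo sapiens) for inhibition, read by MTT assay, with a stated time of 72 h, tested at 10 uM (a lower number here means less inhibition, a higher number more inhibition at the concentration tested (going by the name of the read-out)), compound 1 gives 14.7%.
Compound 2, `CCOC(=O)C1=C(Nc2ccccc2)S/C(=C\c2ccc(Br)c(O)c2)C1=O`: in this assay compound 2 gives 16.4%.
Compound 3, `CCOC(=O)C1=C(Nc2ccccc2)S/C(=C\c2ccc[nH]2)C1=O`: in this assay compound 3 gives 18.3%.

Compound 3 carries the largest of the three numbers, but its steps to the others are small: a number 1.9 percentage points higher from compound 2 to compound 3 (within the scatter) and a number 3.6 percentage points higher from compound 1 to compound 3 (within the scatter), both within the scatter, as is a number 1.7 percentage points higher from compound 1 to compound 2 (within the scatter). The three values therefore cannot be told apart.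

Compound 4, `CCOC(=O)C1=C(Nc2ccc(C)cc2)S/C(=C\c2ccc[nH]2)C1=O`, differs from compound 3 in one place: methyl in place of hydrogen on an aromatic carbon. All three measured steps change the group on the double-bonded chain carbon and leave the anilino part untouched, so none of them bears directly on this change. What they do show is that varying one part of the shared core has moved the inhibition by no more than the scatter. With nothing pointing either way, compound 4 is expected to give a number close to that of compound 3, with an estimated step of a number 0.3 percentage points lower from compound 3 to compound 4 (within the scatter), in this assay. The estimate for compound 4 is 18%, between 7% and 30%.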

Compound 4, a percentage reported as inhibition, at one concentration (the size of the read-out at that concentration, not a potency): < 10%
Compound 4: a limit, no number (the forecaster's own chance of this, stated with the estimate: 2%); at least 8 percentage points between middle value and limit.
By their numbers in this assay, from the lowest: compounds 1, 2 and 3 (each within the scatter of the next). At a limit, below all of these: compound 4.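

Compound 4 gives < 10% in this assay, which is a limit of the assay and not a number. Among the compounds shown, this is the only change in the anilino part of the shared core, and it gives a first reading for this position, para to a large group: with methyl in place of hydrogen, the step is a number at least 8.3 percentage points lower from compound 3 to compound 4 (that floor lies within the scatter). The step may therefore be larger than the earlier ones, but what is known about it rests on the limit alone: the limit of < 10% in this assay, at which 1 of the 4 values shown sits.

Going by these compounds, whether compound 4 truly lies beyond the scatter from compound 3 stays open. Also open, on these data alone, is whether another group at this place, such as methoxy, chlorine or a carboxylic acid, would read like methyl, and whether methyl would act the same alongside the 4-methoxyphenyl group of compound 1.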